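The compounds below may be only part of what the source reports. "The series", "measured", "known", "first", "only" and "open" are said of these compounds alone.

Measured in an ADME assay on MT4 cells (Homo sapiens) for cytotoxicity, read by MTT assay; on this read-out lower numbers stand for higher toxicity in this test and higher numbers for lower toxicity in this test:
- compound 1, `COc1cccc2c1c(C(=O)/C=C(\O)C(=O)O)cn2Cc1ccc(F)c(F)c1`: 71000 nM
- compound 2, `COc1cccc2c1c(C(=O)/C=C(\O)C(=O)O)cn2Cc1ccc(F)cc1`: 41100 nM
- compound 3, `COc1cccc2c1c(C(=O)/C=C(\O)C(=O)O)cn2Cc1cc(F)c(F)c(F)c1`: 23300 nM

Compound 3 stands apart from compound 1 by a step beyond the scatter, a 3.0-fold lower number from compound 1 to compound 3 (0.48 log units; beyond the scatter), while its number and that of compound 2 lie within the scatter of each other, a 1.8-fold lower number from compound 2 to compound 3 (0.25 log units; within the scatter). Compound 4, `COc1cccc2c1c(C(=O)/C=C(\O)C(=O)O)cn2Cc1cccc(F)c1`, differs from compound 3 in one place: 3-fluorophenyl in place of 3,4,5-trifluorophenyl on a saturated chain carbon bound to an aromatic nitrogen.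

Two of the measured steps bear on this change. The step from 4-fluorophenyl to 3,4,5-trifluorophenyl, a 1.8-fold lower number from compound 2 to compound 3 (0.25 log units; within the scatter), moved the number only within the scatter; the addition of one fluoro on the aromatic carbon, a 3.0-fold lower number from compound 1 to compound 3 (0.48 log units; beyond the scatter), moved it modestly downward. Compound 4 runs in the opposite sense, taking two fluorines away and keeping a single one, so a modest move upward in this assay is expected, about the size of those steps or smaller, and it may well stay within the scatter. Compound 4 is therefore expected to give 45000 nM, with a range from 20000 nM to 100000 nM. The expected step is a 1.9-fold higher number from compound 3 to compound 4 (0.29 log units; within the scatter).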

Compound 4, half-maximal cytotoxic concentration: 65800 nM
For compound 4 the middle estimate is 1.5-fold (0.17 log units) below the measured one; the range from low to high includes it.
By their numbers in this assay, from the lowest: compounds 3, 2, 4 and 1 (each within the scatter of the next, the first and the last beyond it).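

In this assay, the step of a 2.8-fold higher number from compound 3 to compound 4 (0.45 log units; beyond the scatter) is beyond the scatter, so the 3,4,5-trifluorophenyl group on the saturated chain carbon bound to an aromatic nitrogen now stands apart from 3-fluorophenyl, as it already stood apart from the group of compound 1. The 3-fluorophenyl group itself cannot be told from the neighbouring groups, since both a 1.6-fold higher number from compound 2 to compound 4 (0.20 log units; within the scatter) and a 1.1-fold lower number from compound 1 to compound 4 (0.03 log units; within the scatter) lie within the scatter. Among these four compounds, then, only compound 3 is separated from any other, and only from compound 1 and compound 4, while compound 2 remains within the scatter of all three, so moving a single fluoro or adding one to the ring shows no effect that can be read apart from the scatter.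

Nothing available explains why compound 3 separates from compound 1 and compound 4. As far as these compounds go, it stays open how the unsubstituted benzyl group, or a ring carrying chloro or methoxy in place of fluoro, would stand in this assay.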